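This account rests on a few compounds, and the source may have more. Where it says the series, first, only, none or still open, it means among the compounds named here.

Compound 1 `CC(C)=CCC/C(C)=C/C[C@]12C[C@@H](CC=C(C)C)C(C)(C)[C@](C/C=C(\C)CCC=C(C)C)(C(=O)C(C(=O)c3ccc(O)c(O)c3)=C1O)C2=O`: in a functional assay on SGC-7901 cells (Homo sapiens) for inhibition (a lower number here means a stronger inhibitor, a higher number a weaker inhibitor), compound 1 gives > 20 ug/mL, which is a limit of the assay and not a number.
Compound 2 `CC(C)=CCC/C(C)=C/C[C@]12C[C@@H](CC=C(C)C)C(C)(C)[C@](CC=C(C)C)(C(=O)C(C(=O)c3ccc(O)c(O)c3)=C1O)C2=O`: compound 2 gives 5.48 ug/mL.
Compound 3 `CC(C)=CCC/C(C)=C/C[C@@H]1C[C@@]2(C/C=C(\C)CCC=C(C)C)C(=O)CC(=O)[C@](CC=C(C)C)(C2=O)C1(C)C`: compound 3 gives > 20 ug/mL, also a limit of the assay rather than a number.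

Compound 3 therefore stands at the limit, and only a range is known for it; the limit of > 20 ug/mL in this assay, at which 2 of the 3 values shown sit, marks where two of the three values shown sit. Compound 4 `CC(C)=CCC/C(C)=C/C[C@@H]1C[C@@]2(CC=C(C)C)C(=O)CC(=O)[C@](CC=C(C)C)(C2=O)C1(C)C` differs from compound 3 in one place: hydrogen in place of 3-methylbut-2-en-1-yl on a saturated chain carbon bound to a double-bonded chain carbon. The very same change has been measured once among the compounds above, namely an at least 3.6-fold lower number from compound 1 to compound 2 (0.56 log units; beyond the scatter). Within the data shown here, that is the only measured step that bears on the change from compound 3 to compound 4, and it points to a lower number, a step of at least modest size. A step of similar direction and size is therefore expected here, so that compound 4 should give a lower number than compound 3, roughly an at least 2.5-fold lower number from compound 3 to compound 4 (0.39 log units; beyond the scatter). Since compound 3 has only a limit, the exact size of the step cannot be fixed from the data. For compound 4 the estimate in this assay is 8 ug/mL, with an expected range from 3 ug/mL to 25 ug/mL.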

Compound 4, half-maximal inhibitory concentration: 6.89 ug/mL
For compound 4 the middle estimate is 1.2-fold (0.06 log units) above the measured one, within the range that was stated.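

In this assay, cutting the 3,7-dimethylocta-2,6-dien-1-yl chain back to 3-methylbut-2-en-1-yl gives an at least 2.9-fold lower number from compound 3 to compound 4 (0.46 log units; beyond the scatter), so this change no longer rests on a single pair of compounds. It now points the same way on two different cores, and each step lies beyond the scatter: the same change on two cores in this assay, an at least 3.6-fold lower number (0.56 log units; beyond the scatter) from compound 1 to compound 2 and an at least 2.9-fold lower number (0.46 log units; beyond the scatter) from compound 3 to compound 4; the limit leaves it open whether they differ Each step starts from a limit of the assay and not a number, so neither step has a known full size: the limit of > 20 ug/mL in this assay, at which 2 of the 4 values shown sit.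

The compounds shown carry only these two chains at this place, so it stays open whether a still shorter group such as methyl, or a chain ending in a carboxylic acid or an amine, would lower the number further or raise it again. As far as these compounds go, it also stays open whether the same shortening would give a step in the same direction on the other chains of these cores, or in any assay other than this assay.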